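A few compounds are considered here, and "the series" means these few. Any claim that something is new, unique, unknown or untested is made for them only; others in the source may bear on it.

Measured so far:
Compound 1, `COc1cc(Cc2nc3c(N)nc(F)nc3n2CC2CCCO2)cc(OC)c1OC`: 22900 nM
Compound 2, `CCC(CC)Cn1c(Cc2cc(OC)c(OC)c(OC)c2)nc2c(N)ncnc21`: 158000 nM
Compound 3, `COCCn1c(Cc2cc(OC)c(OC)c(OC)c2)nc2c(N)nc(F)nc21`: 64600 nM

In a functional assay on MCF7 cells (Homo sapiens) for antiproliferative activity (on this read-out lower numbers stand for stronger inhibition and higher numbers for weaker inhibition), compound 2 gives the highest number of the three, so it is the weakest of these compounds; compound 3 sits nearest to it and compound 1 furthest away, both gaps beyond the scatter. Compound 4, `COc1cc(Cc2nc3c(N)ncnc3n2C)cc(OC)c1OC`, has not yet been measured. It differs from compound 2 in one place: hydrogen in place of pentan-3-yl on a saturated chain carbon bound to an aromatic nitrogen.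

Among the compounds with values here, only one measured step touches the same place, the step of a 2.8-fold higher number from compound 1 to compound 3 (0.45 log units; beyond the scatter), where a smaller group took the place of a larger one and the number rose. Within the data shown here, the change from compound 2 to compound 4 also shrinks the group on that carbon, but goes much further, down to a bare hydrogen, and no measured pair shows that. Among the measured compounds shown here, the direction is therefore unclear; the one step hints at a weaker compound, while compound 2, carrying the largest group, is already the weakest of the three. The expectation is a step of about a 1.3-fold lower number from compound 2 to compound 4 (0.12 log units; within the scatter), within the scatter. Compound 4 is expected to give about 120000 nM in this assay, in a range from 35000 nM to 400000 nM.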

Compound 4, half-maximal inhibitory concentration: 70800 nM
Estimate against measurement, compound 4: 1.7-fold (0.23 log units) above; the measured number falls inside the stated range.
By their numbers in this assay, from the lowest: compound 1; then compounds 3 and 4 (each within the scatter of the next); then compound 2.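

In this assay, taking away pentan-3-yl on the saturated chain carbon bound to an aromatic nitrogen, which turns 2-ethylbutyl into methyl, gives a 2.2-fold lower number from compound 2 to compound 4 (0.35 log units; beyond the scatter). Within the data shown here, this is the first step showing that a smaller group at this place can go with a lower number, the opposite direction to a 2.8-fold higher number from compound 1 to compound 3 (0.45 log units; beyond the scatter), where methoxymethyl replaced oxolan-2-yl; across these two steps, shrinking the group does not move the number one way. Nothing measured here explains why the two steps run in opposite directions.

The compounds shown leave open how an ethyl or propyl chain, or a chain ending in an amine, would compare with methyl and 2-ethylbutyl at this place. From the compounds shown here alone, whether the same change runs the same way on the fluorine-bearing core of compound 1 and compound 3 also stays open.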